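Working notes: from compound 1 to compound 4

The source may hold more compounds than are shown below. What is called first, only, known or untested is meant among the compounds shown, and "the series" means these compounds.

compound 1 `Cc1ccnc(OC(c2ccc(C(F)(F)F)cc2)C2CCN(C(C)CCNC(=O)c3c(Cl)cncc3Cl)CC2)c1` gives 33600 nM
compound 2 `Cc1cccc(OC(c2ccc(Br)cc2)C2CCN(C(C)CCNC(=O)c3c(Cl)cncc3Cl)CC2)n1` gives 6500 nM
compound 3 `CCO/N=C(/c1ccc(Br)cc1)C1CCN(C(C)CCN(C)C(=O)c2c(C)cc[n+]([O-])c2C)CC1` gives > 182000 nM as a limit of the assay

In an ADME assay on PBMC cells (Homo sapiens) for cytotoxicity (on this read-out lower numbers stand for higher toxicity in this test and higher numbers for lower toxicity in this test), compound 1 at 33600 nM stands highest of the two actual numbers, and compound 2 lies lower by a gap beyond the usual scatter. Compound 3 carries a limit, not a number.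

Compound 4 `COc1cccc(OC(c2ccc(C(F)(F)F)cc2)C2CCN(C(C)CCNC(=O)c3c(Cl)cncc3Cl)CC2)n1` is still unmeasured: 6-methoxypyridin-2-yl in place of 4-methylpyridin-2-yl on an oxygen on a saturated carbon puts 6-methoxypyridin-2-yl in place of 4-methylpyridin-2-yl on an oxygen on a saturated carbon. Among the compounds with values here, no measured step isolates this change, so the only guide is the spread of values, with compound 2 at 6500 nM as the lower number. The expected 2.2-fold lower number from compound 1 to compound 4 (0.35 log units; beyond the scatter) is small and downward. For compound 4 the estimated value is 15000 nM with 5000 nM to 45000 nM as the expected range.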

Compound 4, half-maximal cytotoxic concentration: 32700 nM
Estimate against measurement, compound 4: 2.2-fold (0.34 log units) below, and the stated range covers the measured number.
By their numbers in this assay, from the lowest: compound 2; then compounds 4 and 1 (each within the scatter of the next). At a limit, above all of these: compound 3.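

In this assay, the exchange of 4-methylpyridin-2-yl for 6-methoxypyridin-2-yl on an oxygen on a saturated carbon gives a 1.0-fold lower number from compound 1 to compound 4 (0.01 log units; within the scatter). Within the data shown here, this is the only single-place step, and it shows that this position tolerates the added oxygen and the altered substitution pattern on the pyridine with no change in this read-out. Nothing measured here gives a cause for this result.

Going by these compounds, it remains open whether this tolerance extends to an amine or a carboxylic acid on the pyridine ring. A single step also cannot show whether the same exchange would behave alike on another version of the core.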